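The source may report more compounds than this note shows. Statements on the series, on what has been measured and on what is new or still open speak of the compounds shown alone.

Measured in a functional assay on PC-3 cells (Homo sapiens) for antiproliferative activity, read by MTT assay, with a stated time of 24 h; on this read-out lower numbers stand for stronger inhibition and higher numbers for weaker inhibition:
- compound 1 `CCn1c(C(=O)N[C@H](CO)C(C)C)ccc1C(CC)(CC)c1ccc(OCS(=O)(=O)c2ccccc2)c(C)c1`: 7300 nM
- compound 2 `CCn1c(C(=O)N[C@@H](CO)CCCO)ccc1C(CC)(CC)c1ccc(OCS(=O)(=O)c2ccccc2)c(C)c1`: 13400 nM
- compound 3 `CCn1c(C(=O)N[C@H](C)C(=O)O)ccc1C(CC)(CC)c1ccc(OCS(=O)(=O)c2ccccc2)c(C)c1`: 20100 nM

Compound 3 gives 20100 nM and stands at the weak end of this small set. The gap is a 2.8-fold higher number from compound 1 to compound 3 (0.44 log units; beyond the scatter), while a 1.5-fold higher number from compound 2 to compound 3 (0.18 log units; within the scatter).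

Compound 4 `CCn1c(C(=O)NC2(C(=O)O)CC2)ccc1C(CC)(CC)c1ccc(OCS(=O)(=O)c2ccccc2)c(C)c1` differs from it by 1-carboxycyclopropyl in place of 1-carboxyethyl on an amide-type nitrogen.

The measured steps all change this same nitrogen substituent, and they stay modest: a 1.8-fold higher number from compound 1 to compound 2 (0.26 log units; within the scatter), alongside the two above. Within the data shown here, none of the measured groups holds a ring, so the change has no direct precedent.

In this assay no shift beyond the scatter is expected, and the estimated step is a 1.1-fold lower number from compound 3 to compound 4 (0.05 log units; within the scatter).

For compound 4 the estimated value is 18000 nM, with an expected range of 8000 nM to 40000 nM.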

Compound 4, half-maximal inhibitory concentration: 26300 nM
For compound 4 the middle estimate is 1.5-fold (0.16 log units) below the measured one; the measured number falls inside the stated range.
By their numbers in this assay, from the lowest: compounds 1, 2, 3 and 4 (each within the scatter of the next, the first and the last beyond it).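

In this assay, 1-carboxycyclopropyl in place of 1-carboxyethyl on the amide-type nitrogen gives a 1.3-fold higher number from compound 3 to compound 4 (0.12 log units; within the scatter), so the first ring at this position brings no shift beyond the scatter. The other steps read a 2.0-fold higher number from compound 2 to compound 4 (0.29 log units; within the scatter) and a 3.6-fold higher number from compound 1 to compound 4 (0.56 log units; beyond the scatter); the second of these, like the earlier step to the open-chain acid, lies beyond the scatter. Nothing at hand explains these numbers.

On these data alone, whether a cyclobutyl or cyclohexyl ring carrying the carboxylic acid would behave the same stays open. So does the effect of an amine or a methyl ester in place of that acid.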